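Cytotoxicity notes: from compound 1 towards compound 3

This account rests on a few compounds, and the source may have more. Where it says the series, first, only, none or still open, it means among the compounds named here.

Compound 1 `CC(C)C[C@H](NC(=O)[C@]1(Cc2ccccc2)CCN1C(=O)OCc1ccccc1)C(N)=O` carries a 1-carbamoyl-3-methylbutyl group on the amide-type nitrogen of the shared core. For the measured compounds named here, in an ADME assay on HELF cells (Homo sapiens) for cytotoxicity, with a stated time of 3 days (on this read-out lower numbers stand for higher toxicity in this test and higher numbers for lower toxicity in this test), compound 1 gives 50000 nM, the only plain number recorded so far. Compound 2 `NC(=O)[C@H](CCC(=O)O)NC(=O)C1(Cc2ccccc2)CCN1C(=O)OCc1ccccc1` is the other measured analogue. In this assay compound 2 is recorded only as a limit, > 100000 nM, as noted in the limit of > 100000 nM in this assay, at which 1 of the 2 values shown sits. Going by the values given here, no single-point step between measured compounds exists, and compound 1 and compound 2 differ in more than one place, so their two values can only be set side by side. Compound 3 `C[C@H](NC(=O)[C@]1(Cc2ccccc2)CCN1C(=O)OCc1ccccc1)C(=O)NC1CCCCC1` is not yet measured. It differs from compound 1 by 1-(cyclohexylcarbamoyl)ethyl in place of 1-carbamoyl-3-methylbutyl on an amide-type nitrogen. Among the compounds with values here, with no measured step to lean on, the expected step of a 1.3-fold lower number from compound 1 to compound 3 (0.10 log units; within the scatter) is small, within or barely beyond the scatter, with no firm direction. Compound 3 is therefore estimated at 40000 nM in this assay, with an expected range from 15000 nM to 100000 nM.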

Compound 3, half-maximal cytotoxic concentration: > 100000 nM
Compound 3 was reported as a limit (the forecaster's own chance of this, stated with the estimate: 30%); middle value at least 2.5-fold (0.39 log units) from the limit.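

For the compounds shown here, the first readable step at this position is an at least 2.0-fold higher number from compound 1 to compound 3 (0.30 log units; that floor lies within the scatter), for 1-(cyclohexylcarbamoyl)ethyl in place of 1-carbamoyl-3-methylbutyl on an amide-type nitrogen. The entering group brings a six-membered non-aromatic ring of carbon only to this place, yet in this assay the step is only a floor, so its true size cannot be read. Compound 3 is recorded as a limit, > 100000 nM, not as a number, and the series now gathers at that limit: the limit of > 100000 nM in this assay, at which 2 of the 3 values shown sit.

Going by these compounds alone, the true value of compound 3 stays open, and compound 1 remains the only plain number. Also open, as far as these compounds go, is how an amine on the cyclohexyl ring, or a longer chain in place of the ethyl part, would read at this place.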